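Cycloheptyl on the imidazole nitrogen of compound 1's core

This account rests on a few compounds, and the source may have more. Where it says the series, first, only, none or still open, it means among the compounds named here.

Compound 1 `CCC(CC)n1c(-c2ccc(OCc3c(-c4c(Cl)cccc4Cl)noc3C(C)C)cc2)nc2ccc(C(=O)O)cc21` gives 5690 nM in an assay on HEK-293T cells for antagonist activity at vitamin D3 receptor (Homo sapiens), read by a luciferase reporter, with a stated time of 24 h (on this read-out lower numbers stand for stronger inhibition and higher numbers for weaker inhibition), and stands second highest of the three numbers measured. Compound 2 `CCn1c(-c2ccc(OCc3c(-c4c(Cl)cccc4Cl)noc3C(C)C)cc2)nc2ccc(C(=O)O)cc21` gives 5760 nM in this assay, and compound 3 `CC(C)Cn1c(-c2ccc(OCc3c(-c4c(Cl)cccc4Cl)noc3C(C)C)cc2)nc2ccc(C(=O)O)cc21` gives 1180 nM. The step of a 1.0-fold higher number from compound 1 to compound 2 (0.01 log units; within the scatter) is within the scatter; the steps of a 4.8-fold lower number from compound 1 to compound 3 (0.68 log units; beyond the scatter) and a 4.9-fold lower number from compound 2 to compound 3 (0.69 log units; beyond the scatter) are beyond it, each modest.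

Compound 4 `CC(C)c1onc(-c2c(Cl)cccc2Cl)c1COc1ccc(-c2nc3ccc(C(=O)O)cc3n2C2CCCCCC2)cc1` differs from compound 1 by cycloheptyl in place of pentan-3-yl on an aromatic nitrogen. The bearing steps are a 1.0-fold higher number from compound 1 to compound 2 (0.01 log units; within the scatter) and a 4.8-fold lower number from compound 1 to compound 3 (0.68 log units; beyond the scatter): one change at this nitrogen left the number unmoved, the other lowered it modestly. A modest drop or no change beyond the scatter is therefore expected. Compound 4 is estimated at 2800 nM in this assay, between 900 nM and 8500 nM, the expected step being a 2.0-fold lower number from compound 1 to compound 4 (0.31 log units; beyond the scatter).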

Compound 4, half-maximal inhibitory concentration: 921 nM
Compound 4: the middle estimate sits 3.0-fold (0.48 log units) above what was measured; the range from low to high includes it.
By their numbers in this assay, from the lowest: compounds 4 and 3 (each within the scatter of the next); then compounds 1 and 2 (each within the scatter of the next).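

Cycloheptyl, the only ring shown on this aromatic nitrogen, is accepted here in this assay, with a 6.2-fold lower number from compound 1 to compound 4 (0.79 log units; beyond the scatter) and a 6.3-fold lower number from compound 2 to compound 4 (0.80 log units; beyond the scatter). Against isobutyl no separation appears (a 1.3-fold lower number from compound 3 to compound 4 (0.11 log units; within the scatter)), so the four groups fall into two pairs: cycloheptyl with isobutyl at the low end, and pentan-3-yl with ethyl at the high end. No measurement shown bears on why the groups divide this way. Open, on these data alone, is whether cyclopentyl or cyclohexyl would hold the number at this level. Also open, as far as these compounds go, is how a benzyl group or a ring carrying an amine would behave on this nitrogen.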